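The source may report more compounds than this note shows. Statements on the series, on what has been measured and on what is new or still open speak of the compounds shown alone.

Measured so far: compound 1 `CC[S@@+]([O-])CCCCN=C=S`, 19800 nM; compound 2 `C[S@+]([O-])CCCCCN=C=S`, 12000 nM.

Compound 1 holds the higher of the two numbers in a functional assay on A549 cells (Homo sapiens) for cytotoxicity, read by MTT assay, with a stated time of 48 h (a lower number here means a stronger inhibitor, a higher number a weaker inhibitor), but its gap to compound 2 lies within the scatter, so the two compounds cannot be ordered against each other. Compound 3 `CCCC[S@@+]([O-])CCCCN=C=S` differs from compound 1 by ethyl in place of hydrogen on a saturated chain carbon, two bonds along the chain from a sulfur. Within the data shown here, no step between measured compounds bears on this change, so the data give no direction for it. Only a small step is expected, a 1.4-fold lower number from compound 1 to compound 3 (0.15 log units; within the scatter), most likely not beyond the scatter. For compound 3 the estimate in this assay is 14000 nM, with a range from 6000 nM to 35000 nM.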

Compound 3, half-maximal inhibitory concentration: 9770 nM
Compound 3: the middle estimate sits 1.4-fold (0.16 log units) above what was measured; the range from low to high includes it.
By their numbers in this assay, from the lowest: compounds 3, 2 and 1 (each within the scatter of the next, the first and the last beyond it).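

In this assay the change of hydrogen to ethyl on a saturated chain carbon, two bonds along the chain from a sulfur, gives a 2.0-fold lower number from compound 1 to compound 3 (0.31 log units; beyond the scatter) and so supplies the first direction at this position, a modest one toward stronger inhibition. The position therefore accepts the added ethyl without loss of activity in these cells. Nothing measured here accounts for the step.

The compounds shown leave open whether a longer chain on this carbon would carry the trend further, since a single step fixes no trend. They also leave open how a hydroxyl, an amine or a phenyl ring would behave at the same place.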